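The compounds below may be only part of what the source reports. "The series", "measured", "known", "first", "only" and "open" are said of these compounds alone.

Measured so far in a functional assay on A549 cells (Homo sapiens) for cytotoxicity, read by MTT assay, with a stated time of 48 h; a higher number here means a weaker inhibitor, a lower number a stronger inhibitor:
compound 1 `CN1CCN(CCCCOc2c(O)cc(O)c3c(=O)cc(-c4ccccc4)oc23)CC1` gives > 100000 nM, a limit of this assay.
compound 2 `O=c1cc(-c2ccccc2)oc2c(OCCCN3CCCC3)c(O)cc(O)c12` gives > 100000 nM, a limit of this assay.
compound 3 `COc1c(OCCCN2CCCC2)cc(O)c2c(=O)cc(-c3ccccc3)oc12` gives 1390 nM, the only number in the set.

The change from compound 2 to compound 1 is (4-methylpiperazin-1-yl)methyl in place of pyrrolidin-1-yl on a saturated chain carbon, three bonds along the chain from an oxygen on an aromatic ring. Its size is a step that the two limits leave unreadable from compound 2 to compound 1, unreadable because the limit of > 100000 nM in this assay, at which 2 of the 3 values shown sit, holds both ends of the pair. The difference between the core of compound 2 and the core of compound 3 is not broken down here.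

Compound 4 `COc1c(OCCCCN2CCN(C)CC2)cc(O)c2c(=O)cc(-c3ccccc3)oc12` is not yet measured. It arises from compound 3 by the same change, ((4-methylpiperazin-1-yl)methyl in place of pyrrolidin-1-yl on a saturated chain carbon, three bonds along the chain from an oxygen on an aromatic ring), at the same place. No readable step exists for this change, so the expectation rests on compound 3 alone, at 1390 nM, with wide room on either side. The step from compound 3 to compound 4 in this assay is estimated at a 3.6-fold higher number from compound 3 to compound 4 (0.56 log units; beyond the scatter). For compound 4 the estimate is 5000 nM, within 1000 nM to 50000 nM.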

Compound 4, half-maximal inhibitory concentration: 1500 nM
Compound 4: the middle estimate sits 3.3-fold (0.52 log units) above what was measured, within the range that was stated.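

In this assay, on one core only, (4-methylpiperazin-1-yl)methyl in place of pyrrolidin-1-yl gives a 1.1-fold higher number from compound 3 to compound 4 (0.03 log units; within the scatter), so on this core the two groups cannot be told apart. The same change on the other core cannot be read, as compound 2 and compound 1 both stand at a limit: the limit of > 100000 nM in this assay, at which 2 of the 4 values shown sit. The step therefore shows tolerance of the change on a single core and does not show that this result carries from one core to another.

Open, from the compounds shown here alone, is whether morpholin-4-yl or dimethylamino at the end of the chain would stay within the scatter of these values on the core of compound 3. Also open is what separates the two cores, as no pair shown isolates that difference.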